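This account rests on a few compounds, and the source may have more. Where it says the series, first, only, none or still open, it means among the compounds named here.

Compound 1, `CCn1c(CNc2ccccc2)nnc1SCC(=O)Nc1ccc(C(=O)OC)cc1`, gives 540 nM in an assay on isolated protein for inhibition of long-chain fatty acid transport protein 1 (Homo sapiens); a higher number here means a weaker inhibitor, a lower number a stronger inhibitor.
Compound 2, `CCn1c(CNc2ccccc2)nnc1SCc1nc2cc(F)ccc2o1`, gives only a limit of this assay, > 1000 nM.
Compound 3, `CCC(=O)c1ccc2nc(CSc3nnc(CNc4ccccc4)n3CC)oc2c1`, gives 900 nM in this assay.

Among the two numbers in this assay, compound 1 has the lower one, but compound 3 sits within the usual scatter of it, so the two are not told apart. Compound 2 is known only through a limit; the assay reports the limit of > 1000 nM in this assay, at which 1 of the 3 values shown sits, and no number for it. All three share the same core, and the three measurements differ only in the group carried on the sulfur side.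

Compound 4, `CCn1c(CNc2ccccc2)nnc1SCC(=O)Nc1ccc(OC)cc1`, has not been measured yet. It differs from compound 1 in one place: methoxy in place of methoxycarbonyl on an aromatic carbon. For the measured compounds named here, no measured pair shows this change, so the size of the step is not known from the data. With nothing in the measured compounds pointing strongly either way, the step from compound 1 to compound 4 in this assay is expected to be small, at most a modest move toward a weaker inhibitor, a 1.5-fold higher number from compound 1 to compound 4 (0.17 log units; within the scatter). Compound 4 is therefore estimated at 800 nM in this assay, with a range from 300 nM to 2500 nM, and a real chance that only a limit is reported.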

Compound 4, half-maximal inhibitory concentration: > 1000 nM
Compound 4: no number, only a limit (the forecaster's own chance of this, stated with the estimate: 30%); middle value at least 1.2-fold (0.09 log units) away from the limit.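

For the compounds shown here, the exchange of 4-(methoxycarbonyl)phenyl for 4-methoxyphenyl gives the first direct reading of a change on this aromatic carbon, and in this assay it points one way only: an at least 1.8-fold higher number from compound 1 to compound 4 (0.26 log units; that floor lies within the scatter). Taken at its floor, this step cannot be told apart from no change, so the pair alone does not establish a real loss, though the true step may be much larger. Compound 4 is known only through a limit, > 1000 nM, and it joins compound 2 in giving no number, so the set now has as many limits as numbers: the limit of > 1000 nM in this assay, at which 2 of the 4 values shown sit.

The compounds shown leave open how far past the limit compound 4 lies, and so whether the methoxycarbonyl group matters strongly here or only slightly. They also leave open whether it is the carbonyl of this group that counts, a question that a carboxylic acid, a primary amide or a nitrile on the same aromatic carbon would bear on in this assay.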